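This account rests on a few compounds, and the source may have more. Where it says the series, first, only, none or still open, it means among the compounds named here.

Compound 1 `COc1cc2c(Oc3ccc(NC(=O)c4nn(-c5ccc([N+](=O)[O-])cc5)c(=O)c5ccccc45)cc3F)ccnc2cc1OCCCN1CCCC1`: 2980 nM
Compound 2 `COc1cc2c(Oc3ccc(NC(=O)c4nn(-c5ccccc5)c(=O)c5ccccc45)cc3F)ccnc2cc1OCCCN1CCCCC1`: 1880 nM

Both compounds were tested in a functional assay on MDA-MB-231 cells (Homo sapiens) for cytotoxicity, read by MTT assay, with a stated time of 72 h; on this read-out higher numbers stand for weaker inhibition and lower numbers for stronger inhibition. Compound 1 gives 2980 nM, and compound 2 gives 1880 nM. For the measured compounds named here, of the two numbers, the one for compound 2 is the smaller, but its distance to compound 1 lies within the scatter of repeated measurements, so the two compounds cannot be told apart on this evidence.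

Compound 3 `COc1cc2c(Oc3ccc(NC(=O)c4nn(-c5ccc([N+](=O)[O-])cc5)c(=O)c5ccccc45)cc3F)ccnc2cc1OCCCN1CCCCC1` has not yet been measured. It differs from compound 2 in one place: nitro in place of hydrogen on an aromatic carbon. Going by the values given here, no directly comparable pair of measured compounds isolates this change, so the expected step rests on the two numbers above alone. Since compound 1, which also carries the nitro group, sits within the scatter of compound 2, no step beyond the scatter is expected in this assay in either direction.

The estimated step from compound 2 to compound 3 is a 1.3-fold higher number from compound 2 to compound 3 (0.12 log units; within the scatter). Compound 3 is therefore expected to give about 2500 nM, with a likely range from 1000 nM to 6000 nM.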

Compound 3, half-maximal inhibitory concentration: 2620 nM
Beside the measured number, compound 3's estimate is 1.0-fold (0.02 log units) below it; the measured number falls inside the stated range.
By their numbers in this assay, from the lowest: compounds 2, 3 and 1 (each within the scatter of the next).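

In this assay, for the compounds shown here, going from phenyl to 4-nitrophenyl while the piperidin-1-yl end of the chain stays fixed gives a 1.4-fold higher number from compound 2 to compound 3 (0.14 log units; within the scatter), so this position now has a direct comparison in which only the nitro group changes, and that comparison shows no step that can be told from the scatter. The same measurement also opens a second comparison at the far end of the chain, where piperidin-1-yl in place of pyrrolidin-1-yl gives a 1.1-fold lower number from compound 1 to compound 3 (0.06 log units; within the scatter), again within the scatter, so neither single change separates these compounds in this cytotoxicity read-out. No measurement of any other kind accompanies these numbers to explain them.

On these data alone, the aromatic position is represented here only by hydrogen and nitro, and the chain end only by two saturated nitrogen rings, so it remains open whether an amine, a methoxy group or a carboxylic acid on that ring, or a morpholine or a longer chain at the other end, would produce a step beyond the scatter. As far as these compounds go, whether either change would read the same way on another cell line also remains open.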